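The compounds below may be only part of what the source reports. "The series", "measured", "known", "first", "only" and "open" are said of these compounds alone.

Compound 1 `CC(C)(C)[C@H](C(=O)Nc1ncc(F)s1)c1ccc(Cl)cc1` is the starting point. In a functional assay on CHO cells for agonist activity at Free fatty acid receptor 2 (Homo sapiens), read by cAMP accumulation (on this read-out higher numbers stand for weaker inhibition and lower numbers for stronger inhibition), compound 1 gives 700 nM, and its only companion so far is compound 2 `CC(C)(C)[C@H](C(=O)Nc1ncc(C(O)(C(F)(F)F)C(F)(F)F)s1)c1ccc(Cl)cc1`, which in this assay gives 1200 nM. Within the data shown here, the one measured step, a 1.7-fold higher number from compound 1 to compound 2 (0.23 log units; within the scatter), leaves the two numbers indistinguishable, so compound 1 can be called neither stronger nor weaker than compound 2.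

The next compound to be tested is compound 3 `O=C(Nc1ncc(F)s1)[C@H](c1ccc(Cl)cc1)C1CC1`. It differs from compound 1 by cyclopropyl in place of tert-butyl on a saturated chain carbon bound to an aromatic carbon and a carbonyl carbon. The measured step from compound 1 to compound 2 alters a group on an aromatic carbon at the other end of the shared core and leaves the saturated chain carbon untouched, so it offers no direct guide to this change. Without a comparable precedent, the expectation is that the step of a 1.7-fold higher number from compound 1 to compound 3 (0.23 log units; within the scatter) is modest and tilts toward a higher number, with a wide uncertainty. The expected value for compound 3 in this assay is therefore 1200 nM, with a range from 400 nM to 4000 nM.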

Compound 3, half-maximal inhibitory concentration: 1200 nM
Compound 3: middle estimate and measured number agree at the digits printed; the range from low to high includes it.
By their numbers in this assay, from the lowest: compounds 1, 2 and 3 (each within the scatter of the next).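

Moving to the saturated chain carbon bound to an aromatic carbon and a carbonyl carbon, this assay gives a 1.7-fold higher number from compound 1 to compound 3 (0.23 log units; within the scatter) for cyclopropyl in place of tert-butyl. Among these compounds, this is the first measured change at this position, and it shows that these two groups cannot be told apart here, even though one has a three-membered ring of carbon only and the other has no ring. Nothing among the available measurements explains why the two groups read alike.

From the compounds shown here alone, a single step at this position cannot show how much the group there can vary, so it remains open whether a larger ring such as cyclohexyl, a longer chain such as n-butyl, or a nitrogen-bearing group such as an amine would stay within the scatter or move the number clearly away from that of compound 1. Among the compounds shown here, also open is what would happen if cyclopropyl were paired with the 2,2,2-trifluoro-1-hydroxy-1-(trifluoromethyl)ethyl group on the aromatic carbon at the other end of the shared core, since each change has so far been seen only on its own.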